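A few compounds are considered here, and "the series" means these few. Any claim that something is new, unique, unknown or untested is made for them only; others in the source may bear on it.

Measured so far in a functional assay on CHO cells for agonist activity at sphingosine 1-phosphate receptor 5 (Homo sapiens), read by GTPgammaS binding; on this read-out lower numbers stand for an effect already at smaller amounts and higher numbers for an effect only at larger amounts of compound:
Compound 1 `Cc1cc(C(=O)O)ccc1-c1noc(-c2ccc(C3CCCCC3)cc2)n1`. For compound 1 this assay gives only a limit, > 10000 nM (the limit of > 10000 nM in this assay, at which 1 of the 3 values shown sits).
Compound 2 `Cc1cc(CCC(=O)O)ccc1-c1noc(-c2ccc(C3CCCCC3)cc2)n1`. Compound 2 gives 591 nM.
Compound 3 `Cc1cc(CCCC(=O)O)ccc1-c1noc(-c2ccc(C3CCCCC3)cc2)n1`. Compound 3 gives 840 nM.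

Compound 3 holds the highest of the two numbers shown; its nearest neighbour is compound 2, with a 1.4-fold higher number from compound 2 to compound 3 (0.15 log units; within the scatter), a step within the scatter. Compound 4 `Cc1cc(CCCCCC(=O)O)ccc1-c1noc(-c2ccc(C3CCCCC3)cc2)n1` differs from compound 3 by 2-carboxyethyl in place of carboxy on a saturated chain carbon, three bonds along the chain from an aromatic carbon. Among the compounds with values here, of the measured steps, an at least 16-fold lower number from compound 1 to compound 2 (1.22 log units; beyond the scatter) and an at least 11-fold lower number from compound 1 to compound 3 (1.07 log units; beyond the scatter) were large but run out from a limit and so set no size for a further chain extension; the only step between two real numbers, a 1.4-fold higher number from compound 2 to compound 3 (0.15 log units; within the scatter), stayed within the scatter. For compound 4 a modest step toward a higher number is therefore expected, a 1.8-fold higher number from compound 3 to compound 4 (0.25 log units; within the scatter), close to the scatter. Compound 4 is estimated at 1500 nM, with a range from 500 nM to 5000 nM.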

Compound 4, half-maximal effective concentration: 1080 nM
Compound 4: middle estimate off by 1.4-fold (0.14 log units), on the high side; the range from low to high includes it.
By their numbers in this assay, from the lowest: compounds 2, 3 and 4 (each within the scatter of the next). At a limit, above all of these: compound 1.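

In this assay the extension at this place gives a 1.3-fold higher number from compound 3 to compound 4 (0.11 log units; within the scatter) and the wider span gives a 1.8-fold higher number from compound 2 to compound 4 (0.26 log units; within the scatter) so no dependence on length shows up even at the 5-carboxypentyl chain. With this longest chain shown, the distance from the directly attached carboxy still stands as an at least 9.2-fold lower number from compound 1 to compound 4 (0.96 log units; beyond the scatter) and lies beyond the scatter. Compound 1 is only a limit, so that step has no upper size: the limit of > 10000 nM in this assay, at which 1 of the 4 values shown sits.

Still open, as far as these compounds go, is whether a chain longer than 5-carboxypentyl stays level with compounds 2, 3 and 4. Also open, from the compounds shown here alone, is whether an amine in place of the carboxylic acid keeps any effect.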